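A Pyrazole Amide Expected to Stay Well Tolerated

The source may hold more compounds than are shown below. What is called first, only, known or untested is meant among the compounds shown, and "the series" means these compounds.

Compound 1 `COc1ccc(-c2cnc(NC(=O)c3cccc(OC)c3)n2C)cc1` was tested in a toxicity assay on THP-1 cells (Homo sapiens) for inhibition; a higher number here means that more compound is tolerated, a lower number that less compound is tolerated. In this assay compound 1 gives > 100000 nM, which is a limit of the assay and not a number. Compound 2 `Cn1c(-c2ccccc2)cnc1NC(=O)c1ncc[nH]1` likewise gives > 100000 nM, again a limit. the limit of > 100000 nM in this assay, at which 2 of the 2 values shown sit. Compound 3 `COc1ccc(-c2cnc(NC(=O)c3ccn[nH]3)n2C)cc1` differs from compound 1 in one place: 1H-pyrazol-5-yl in place of 3-methoxyphenyl on a carbonyl carbon. Going by the values given here, no measured pair shows this change, and both known values sit at the limit; no step beyond the scatter is expected in this assay. Compound 3 is expected to give 100000 nM, between 50000 nM and 200000 nM. The step of a number no higher from compound 1 to compound 3 (the limit leaves the size open) is expected to lie within the scatter.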

Compound 3, half-maximal cytotoxic concentration: > 100000 nM
Compound 3 ended at the assay's limit; the forecaster's own chance of this, stated with the estimate: 85%; the middle value lies on the limit itself.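

No step can be read from compound 1 to compound 3, since both values are limits of the assay and not numbers: the limit of > 100000 nM in this assay, at which 3 of the 3 values shown sit.

Still open is whether 1H-pyrazol-5-yl in place of 3-methoxyphenyl changes tolerance at all, and at what concentration any of these compounds would become toxic.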